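A Fourth Side Chain on a Shared Core

The source may report more compounds than this note shows. Statements on the series, on what has been measured and on what is new or still open speak of the compounds shown alone.

In a functional assay on HeLa cells (Homo sapiens) for cytotoxicity, read by MTT assay (a higher number here means a weaker inhibitor, a lower number a stronger inhibitor), compound 1 (`CC(C)=CC[C@@H](OC[C@H](C)O)C1=CC(=O)c2c(O)ccc(O)c2C1=O`) gives 40300 nM, compound 2 (`COC(C)CO[C@H](CC=C(C)C)C1=CC(=O)c2c(O)ccc(O)c2C1=O`) gives 53400 nM, and compound 3 (`CC[C@](C)(O)CC(=O)O[C@H](CC=C(C)C)C1=CC(=O)c2c(O)ccc(O)c2C1=O`) gives 30200 nM. Compound 3 thus stands within the scatter of both others. Compound 4 (`CC(=O)OC(C)CO[C@H](CC=C(C)C)C1=CC(=O)c2c(O)ccc(O)c2C1=O`) carries 2-acetoxypropyl in place of (2-hydroxy-2-methylbutyl)carbonyl on an oxygen on a saturated carbon. The measured changes at this side chain were all small: a 1.3-fold higher number from compound 1 to compound 2 (0.12 log units; within the scatter), a 1.3-fold lower number from compound 1 to compound 3 (0.13 log units; within the scatter), and a 1.8-fold lower number from compound 2 to compound 3 (0.25 log units; within the scatter). All three lie within the scatter, so no clear shift is expected in this assay. The expected change is a 1.3-fold higher number from compound 3 to compound 4 (0.10 log units; within the scatter), in no firm direction. For compound 4 the estimated value is 38000 nM, with an expected range of 19000 nM to 75000 nM.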

Compound 4, half-maximal inhibitory concentration: 40100 nM
Compound 4: middle estimate off by 1.1-fold (0.02 log units), on the low side, and the stated range covers the measured number.
By their numbers in this assay, from the lowest: compounds 3, 4, 1 and 2 (each within the scatter of the next).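

In this assay, 1-acetoxyethyl in place of 1-hydroxyethyl (a 1.0-fold lower number from compound 1 to compound 4 (0.00 log units; within the scatter)) and acetyl in place of methyl on an oxygen on a saturated carbon (a 1.3-fold lower number from compound 2 to compound 4 (0.12 log units; within the scatter)) leave the number within the scatter. So does 2-acetoxypropyl in place of (2-hydroxy-2-methylbutyl)carbonyl (a 1.3-fold higher number from compound 3 to compound 4 (0.12 log units; within the scatter)), so an acetyl end on this side chain now joins the hydroxyl and methyl ends with no clear shift. Nothing given here accounts for this flat picture. On these data alone, whether an amine, a carboxylic acid or a longer chain at this oxygen would move the number beyond the scatter remains open.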